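Aryl-piperazine succinimide amides: ortho trifluoromethyl analogue

The source may hold more compounds than are shown below. What is called first, only, known or untested is meant among the compounds shown, and "the series" means these compounds.

Compound 1 `CC(C(=O)N1CCN(c2ccccc2F)CC1)N1C(=O)CCC1=O` is the head of this small set: in a functional assay on the whole organism (strain Swiss) with Mus musculus as the target, in the maximal electroshock model, with a stated time of 1 h, at a dose of 300 mg/kg by the intraperitoneal route (a higher number here means a stronger effect of the compound at the dose given, a lower number a weaker effect), compound 1 gives 50%. Compound 3 `CC(C(=O)N1CCN(c2ccc(F)cc2)CC1)N1C(=O)CCC1=O` gives 25% in this assay, and compound 2 `CC(C(=O)N1CCN(c2ccc(C(F)(F)F)cc2)CC1)N1C(=O)CCC1=O` gives 0%. The change a number 25 percentage points lower from compound 1 to compound 3 (beyond the scatter) goes with the core difference (2-fluorophenyl in place of 4-fluorophenyl on an amine nitrogen in a ring). Within the core of compound 3, the change a number 25 percentage points lower from compound 3 to compound 2 (beyond the scatter) accompanies (trifluoromethyl in place of fluoro on an aromatic carbon).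

Compound 4 `CC(C(=O)N1CCN(c2ccccc2C(F)(F)F)CC1)N1C(=O)CCC1=O` has not been measured. It differs from compound 1 by trifluoromethyl in place of fluoro on an aromatic carbon. This is the same kind of change as that from compound 3 to compound 2, but the place differs: here the group sits ortho to a large group, there para to a large group.

Going by the values given here, the one measured step of this kind is a number 25 percentage points lower from compound 3 to compound 2 (beyond the scatter). Applied to compound 1, which gives 50%, the expected step is a number 25 percentage points lower from compound 1 to compound 4 (beyond the scatter). Compound 4 is estimated at 25%, with a range from 0% to 50%; the placement difference leaves this uncertain.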

Compound 4, a percentage reported as activity, at one dose (the size of the read-out at that dose, not a potency): 75%
Compound 4: middle estimate off by 50 percentage points, on the low side; measured number above the stated range.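

Trifluoromethyl in place of fluoro gives a number 25 percentage points higher from compound 1 to compound 4 (beyond the scatter) in this assay. This change does not carry over from one core to the other with a fixed size or direction: the same change on two cores in this assay, a number 25 percentage points lower (beyond the scatter) from compound 3 to compound 2 and a number 25 percentage points higher (beyond the scatter) from compound 1 to compound 4, 50 percentage points apart, beyond the scatter of two such steps

Going by these compounds alone, with only one step on each core, this does not show that the place of the group on the aromatic ring alone sets the direction, nor how the change would behave on a further core.

The compounds shown leave open whether a chloro or methoxy group ortho to a large group would read like fluoro or like trifluoromethyl. Also open, from the compounds shown here alone, is how either group would read at a dose other than the one used here.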